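A few compounds are considered here, and "the series" means these few. Any claim that something is new, unique, unknown or untested is made for them only; others in the source may bear on it.

Compound 1 `COc1nn2cc(-c3cc4ccccc4o3)nc2s1`: in an assay on a cell-free system (plasma) for antagonist activity at proteinase-activated receptor 4 (Homo sapiens), with a stated time of 5 min, in the presence of a further agent that is not named here (on this read-out lower numbers stand for stronger inhibition and higher numbers for weaker inhibition), compound 1 gives 15000 nM.
Compound 2 `COc1cc(OCc2cccc(C#N)c2)c2cc(-c3cn4nc(OC)sc4n3)oc2c1`: in this assay compound 2 gives 820 nM.
Compound 3 `COc1cc(OC)c2cc(-c3cn4nc(OC)sc4n3)oc2c1`: in this assay compound 3 gives 530 nM.

Among these three, compound 2 stands second highest; its nearest neighbour is compound 3, with a 1.5-fold lower number from compound 2 to compound 3 (0.19 log units; within the scatter), while compound 1 lies far higher. Compound 4 `COc1cc(OCc2cccc(Sc3ccccc3)c2)c2cc(-c3cn4nc(OC)sc4n3)oc2c1` differs from compound 2 in one place: phenylsulfanyl in place of cyano on an aromatic carbon. For the measured compounds named here, no measured step replaces the cyano group directly. The only step that touches this part of the molecule is the one from compound 2 to compound 3, which removes the whole 3-cyanophenyl group and yet stays within the scatter, so changes in this region have so far shown little effect. Compound 4 is therefore expected to stay close to compound 2, with a step of a 1.0-fold lower number from compound 2 to compound 4 (0.01 log units; within the scatter), giving an estimate of 800 nM with a range from 250 nM to 2500 nM.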

Compound 4, half-maximal inhibitory concentration: 410 nM
For compound 4 the middle estimate is 2.0-fold (0.29 log units) above the measured one; low and high end bracket the measured number.
By their numbers in this assay, from the lowest: compounds 4, 3 and 2 (each within the scatter of the next); then compound 1.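

Replacing cyano with phenylsulfanyl on this aromatic carbon puts 7 heavy atoms and a six-membered aromatic ring where 2 heavy atoms stood, yet this assay shows only a 2.0-fold lower number from compound 2 to compound 4 (0.30 log units; within the scatter). The earlier step removed the whole 3-cyanophenyl group, whereas this one shows that a far larger group on that ring also leaves the number within the scatter. No available evidence explains this result. The compounds shown leave open whether an amine or a carboxylic acid on this aromatic carbon would also stay within the scatter of compound 2.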